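The source may report more compounds than this note shows. Statements on the series, on what has been measured and on what is new or still open speak of the compounds shown alone.

Measured so far:
Compound 1 `CC(C)(C)n1cc(-c2cc(C(O)(C(F)(F)F)C(F)(F)F)cnc2N2CCN(S(=O)(=O)c3ccc(N)nc3)CC2)cn1`: 86 mL.min-1.g-1
Compound 2 `Nc1ccc(S(=O)(=O)N2CCN(c3ncc(C(O)(C(F)(F)F)C(F)(F)F)cc3-c3ccncc3)CC2)cn1`: 15 mL.min-1.g-1

Both numbers come from an ADME assay (liver) for metabolic stability, with Liver microsome (Homo sapiens) as the target, using microsomes and NADPH, with a stated time of 30 min, tested at 1 uM; on this read-out lower numbers stand for slow clearance and higher numbers for fast clearance. Of the two, compound 2 holds the lower number, so it is the more slowly cleared. Going by the values given here, the one measured step is a 5.7-fold lower number from compound 1 to compound 2 (0.76 log units; beyond the scatter), and it replaces a 1-(tert-butyl)-1H-pyrazol-4-yl with a pyridin-4-yl on an aromatic carbon.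

Compound 3 `Nc1ccc(S(=O)(=O)N2CCN(c3ncc(C(O)(C(F)(F)F)C(F)(F)F)cc3-c3cnccc3F)CC2)cn1` carries 4-fluoropyridin-3-yl in place of the pyridin-4-yl of compound 2: 4-fluoropyridin-3-yl in place of pyridin-4-yl on an aromatic carbon. The change falls at the same place as that measured step, so a 5.7-fold lower number from compound 1 to compound 2 (0.76 log units; beyond the scatter) shows that this place can move the read-out. That step swapped two quite different groups, however, whereas here both groups are six-membered aromatic rings. Among the compounds with values here, no measured pair tests the added fluorine or the new attachment point. A smaller change is therefore expected, slightly upward if anything. The estimated change is a 1.3-fold higher number from compound 2 to compound 3 (0.12 log units; within the scatter), which would probably stay within the usual scatter. Compound 3 is expected at 20 mL.min-1.g-1, with an estimated range of 9 mL.min-1.g-1 to 45 mL.min-1.g-1.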

Compound 3, intrinsic clearance in microsomes: 17 mL.min-1.g-1
Estimate against measurement, compound 3: 1.2-fold (0.07 log units) above; low and high end bracket the measured number.
By their numbers in this assay, from the lowest: compounds 2 and 3 (each within the scatter of the next); then compound 1.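

At this position, next to the pyridin-4-yl of compound 2, the fluorinated ring of compound 3 leaves the read-out of this assay unmoved in any way that can be told apart (a 1.1-fold higher number from compound 2 to compound 3 (0.05 log units; within the scatter)), so a fluorine and a different attachment point on the pyridine ring can be accepted here together without a visible cost. The large gap to the tert-butyl pyrazole also appears a second time, as a 5.1-fold lower number from compound 1 to compound 3 (0.70 log units; beyond the scatter), so in these three compounds both pyridine-bearing groups sit beyond the scatter from the 1-(tert-butyl)-1H-pyrazol-4-yl group, and no compound shown goes against this. Nothing measured here says why the two pyridine rings read alike or why the pyrazole differs.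

Compound 3 changes the fluorine and the attachment point at once, so two opposing effects cannot be told from no effect at all, and a plain pyridin-3-yl group would be needed to separate them. Going by these compounds, how the position responds to a group of quite another kind, such as a morpholine ring or a carboxylic acid, also stays open.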